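Cyano in place of trifluoromethylsulfanyl: expected tolerance of compound 4

The source may report more compounds than this note shows. Statements on the series, on what has been measured and on what is new or still open speak of the compounds shown alone.

Three compounds share one core and differ only in the group on the amine nitrogen. Compound 1 `Cc1ccc2[nH]c(=O)c(CN(CCCO)Cc3ccc(C(C)(C)C)cc3)cc2c1` carries a 2-hydroxyethyl chain there; in a toxicity assay on MDCK cells (Canis lupus familiaris) for cytotoxicity, read by crystal violet staining, with a stated time of 48 h (a lower number here means that less compound is tolerated, a higher number that more compound is tolerated), compound 1 reaches only the limit > 10000 nM of this assay. Compound 2 `Cc1ccc2[nH]c(=O)c(CN(Cc3ccc(OC(F)F)cc3)Cc3ccc(C(C)(C)C)cc3)cc2c1` bears a 4-(difluoromethoxy)benzyl group, and in this assay compound 2 likewise gives only the limit > 5000 nM. Compound 3 `Cc1ccc2[nH]c(=O)c(CN(Cc3ccc(SC(F)(F)F)cc3)Cc3ccc(C(C)(C)C)cc3)cc2c1` carries a 4-((trifluoromethyl)sulfanyl)benzyl group; in this assay compound 3 also stops at the limit > 5000 nM. Thus compound 3 stands where compound 2 stands, and none of the three values is a number. The steps a step that the two limits leave unreadable from compound 1 to compound 2, a step that the two limits leave unreadable from compound 1 to compound 3 and a step that the two limits leave unreadable from compound 2 to compound 3 are therefore not readable, since the limit of > 10000 nM in this assay, at which 1 of the 3 values shown sits, and the limit of > 5000 nM in this assay, at which 2 of the 3 values shown sit, hold all three values.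

Compound 4 `Cc1ccc2[nH]c(=O)c(CN(Cc3ccc(C#N)cc3)Cc3ccc(C(C)(C)C)cc3)cc2c1` is the next member: cyano in place of (trifluoromethyl)sulfanyl on an aromatic carbon. Among the measured compounds shown here, no measured step shows what a swap of this kind does in this assay; the two that bear on the substituent, a step that the two limits leave unreadable from compound 2 to compound 3 and a step that the two limits leave unreadable from compound 1 to compound 3, are both left unreadable by the limits. With every neighbour tolerated up to its limit, compound 4 is expected to behave the same, so the step that the limit leaves unreadable from compound 3 to compound 4 is estimated to be none beyond the scatter. For compound 4 the estimate in this assay is 9000 nM, with a range from 3000 nM to 30000 nM.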

Compound 4, half-maximal cytotoxic concentration: > 5000 nM
Compound 4 gave a limit, no number; the forecaster's own chance of this, stated with the estimate: 80%; the middle value is on the limit's open side.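

In this assay compound 4 gives > 5000 nM, which is a limit and not a number. Among the compounds shown here, no step linking compound 4 with compound 1, compound 2 or compound 3 can be read. The compounds shown leave open at what concentration any of them stops being tolerated, and whether the groups on the amine nitrogen differ at all in this assay.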